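Turning One Double Bond: Compound 1 to Compound 4

The source may report more compounds than this note shows. Statements on the series, on what has been measured and on what is new or still open speak of the compounds shown alone.

Measured compounds in a functional assay on RAW264.7 cells (Mus musculus) for inhibition, read by ELISA, with stated times of 1 h and 18 h, tested at 5 uM; on this read-out lower numbers stand for a stronger effect and higher numbers for a weaker effect at the one concentration tested:
- compound 1, `C=C1CC[C@H]2C(C)(C)CCC[C@]2(C)[C@H]1C/C=C1/C(=O)OC[C@H]1O`: 40%
- compound 2, `C=C1CC[C@H]2C(C)(C)CCC[C@]2(C)[C@H]1C[C@@H](O)C1=CCOC1=O`: 75.6%
- compound 3, `C=C1CC[C@H]2C(C)(C)CCC[C@]2(C)[C@H]1C/C=C1\CC(OC)OC1=O`: 70%

Among these three, compound 1 gives the lowest number in this assay, which here means the strongest effect. Its nearest neighbour is compound 3, whose value lies a long way higher, beyond the scatter of repeat measurements, and compound 2 lies further still. Compound 1 is therefore the clear standout of the three that have been measured.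

The next compound, compound 4, `C=C1CC[C@H]2C(C)(C)CCC[C@]2(C)[C@H]1C/C=C1\C(=O)OC[C@H]1O`, keeps the whole skeleton of compound 1. Its only difference is the two compounds have the same atoms and bonds and differ only in configuration as drawn: 1 of 5 stereo elements differ; a double bond is drawn E in compound 1 and Z in compound 4. For the measured compounds named here, no pair of measured compounds shows what such a change alone does here, so the size of the step has to be guessed rather than read off.

A change of this kind can leave the number where it is or move it considerably in either direction. The step of a number 15 percentage points higher from compound 1 to compound 4 (beyond the scatter) is expected to be a moderate weakening, since compound 1 already sits at the strong end of the measured range. For compound 4 the estimated value in this assay is 55%, expected to fall between 30% and 85%.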

Compound 4, a percentage reported as activity, at one concentration (the size of the read-out at that concentration, not a potency): 32.2%
Compound 4: the middle estimate sits 22.8 percentage points above what was measured; low and high end bracket the measured number.
By their numbers in this assay, from the lowest: compounds 4 and 1 (each within the scatter of the next); then compounds 3 and 2 (each within the scatter of the next).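

This pair gives a clean reading of one feature, the geometry of the double bond, and the reason it is clean is simple: the fact that compounds 1 and 4 differ only in the configuration as drawn. In this assay, drawing that double bond Z rather than E gives a number 7.8 percentage points lower from compound 1 to compound 4 (within the scatter), so at this one concentration the two geometries cannot be told apart. For the compounds shown here, neither the earlier compounds nor the opening estimate could settle this point, but the pair now shows that the read-out here does not depend measurably on this geometry, and the marked effect seen for compound 1 is shared by compound 4.

As far as these compounds go, both numbers come from a single concentration, so it remains open whether the two geometries would also match at other concentrations, where one could still give a stronger or weaker effect than the other. Also open, from the compounds shown here alone, is how much the effect depends on the hydroxyl group that compound 1 and compound 4 share, for instance whether an amine or a carboxylic acid in its place would keep the read-out in the same range.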